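Cytotoxicity notes on the allyloxy chalcone series

The compounds below may be only part of what the source reports. "The series", "measured", "known", "first", "only" and "open" are said of these compounds alone.

Three compounds of the shared core carry the measurement so far. Compound 1 `C=CCOc1cc(OC)c(C(=O)/C=C/c2ccc(O)cc2)c(OCC=C)c1` gives 76400 nM in an ADME assay on Vero cells (Chlorocebus sabaeus) for cytotoxicity, read by MTT assay; on this read-out lower numbers stand for stronger inhibition and higher numbers for weaker inhibition. Compound 2 `C=CCOc1cc(OC)c(C(=O)/C=C/c2cccc(OC)c2)c(OCC=C)c1` gives 142000 nM in the same read-out; the step of a 1.9-fold higher number from compound 1 to compound 2 (0.27 log units; within the scatter) is within the scatter, so nothing is read from that pair. Compound 3 `C=CCOc1cc(OC)c(C(=O)/C=C/c2ccc(C(F)(F)F)cc2)c(OCC=C)c1` gives 7200 nM and stands lowest of the three numbers, with compound 1 its nearest neighbour and compound 2 the furthest; both steps onto it, an 11-fold lower number from compound 1 to compound 3 (1.03 log units; beyond the scatter) and a 20-fold lower number from compound 2 to compound 3 (1.29 log units; beyond the scatter), are large and beyond the scatter.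

Compound 4 `C=CCOc1cc(OC)c(C(=O)/C=C/c2ccncc2)c(OCC=C)c1` is the next to be measured. It differs from compound 3 by pyridin-4-yl in place of 4-(trifluoromethyl)phenyl on a double-bonded chain carbon bound to a double-bonded chain carbon. The two steps that bear on this change are those toward compound 3, in which the trifluoromethyl group replaced a hydroxy or methoxy-bearing ring and the number fell by an 11-fold lower number from compound 1 to compound 3 (1.03 log units; beyond the scatter) and a 20-fold lower number from compound 2 to compound 3 (1.29 log units; beyond the scatter). Compound 4 removes the trifluoromethyl group again and introduces a ring with one acceptor, as the hydroxy and methoxy partners of compounds 1 and 2 also have, so the number is expected to climb back toward those two. For compound 4 the estimated value in this assay is 60000 nM, with a range from 15000 nM to 200000 nM, an expected step of an 8.3-fold higher number from compound 3 to compound 4 (0.92 log units; beyond the scatter).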

Compound 4, half-maximal inhibitory concentration: 2800 nM
Compound 4: middle estimate off by 21-fold (1.33 log units), on the high side, outside the stated range (below it).
By their numbers in this assay, from the lowest: compound 4; then compound 3; then compounds 1 and 2 (each within the scatter of the next).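

The pyridin-4-yl ring at this place on the double-bonded chain carbon shows that removing the trifluoromethyl group does not by itself raise the number in this assay, since the change from 4-(trifluoromethyl)phenyl gives a 2.6-fold lower number from compound 3 to compound 4 (0.41 log units; beyond the scatter) and the step is modest but beyond the scatter. The 4-hydroxyphenyl and 3-methoxyphenyl partners do not predict the result for this ring either, with a 27-fold lower number from compound 1 to compound 4 (1.44 log units; beyond the scatter) and a 51-fold lower number from compound 2 to compound 4 (1.71 log units; beyond the scatter) both large, so a hydrogen-bond acceptor on the ring does not place a compound with those two, and compound 4 now holds the lowest number of the four. No measurement among the data shown accounts for this ordering.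

The compounds shown leave open whether the low number follows the ring nitrogen as such or its place in the ring, a question that pyridin-3-yl or pyridin-2-yl on the same chain carbon would address. Also open, on these data alone, is where unsubstituted phenyl or a ring bearing an amine or a carboxylic acid would fall relative to compound 3 and compound 4 on this read-out.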